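The compounds below may be only part of what the source reports. "The series", "measured", "known", "first", "only" and "open" are said of these compounds alone.

Compound 1 `CCOC(=O)N(C)CC#CCN1CCCC1`: in a functional assay on the whole organism for agonist activity, with Mus musculus as the target (on this read-out higher numbers stand for an effect only at larger amounts of compound and lower numbers for an effect already at smaller amounts), compound 1 gives > 100 mg/kg, which is a limit of the assay rather than a number.
Compound 2 `CCOC(=O)N(C)CC#CCn1ccnc1`: in this assay compound 2 gives > 100 mg/kg, again only a limit.
Compound 3 `CCOC(=O)N(C)C(C)C#CCN1CCCC1`: in this assay compound 3 gives > 100 mg/kg, also a limit.

Compound 2 differs from compound 1 by 1H-imidazol-1-yl in place of pyrrolidin-1-yl on a saturated chain carbon bound to a triple-bonded carbon; the resulting step is a step that the two limits leave unreadable from compound 1 to compound 2. Compound 3 differs from compound 1 in its core by methyl in place of hydrogen on a saturated chain carbon bound to an amide-type nitrogen and a triple-bonded carbon; that step is a step that the two limits leave unreadable from compound 1 to compound 3. All three measured values therefore sit at the limit of > 100 mg/kg in this assay, at which 3 of the 3 values shown sit.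

Compound 4 `CCOC(=O)N(C)C(C)C#CCn1ccnc1` has not yet been measured. It differs from compound 3 by 1H-imidazol-1-yl in place of pyrrolidin-1-yl on a saturated chain carbon bound to a triple-bonded carbon, the same change that was made once before and gave a step that the two limits leave unreadable from compound 1 to compound 2. For the measured compounds named here, because every measured value so far sits at the limit of > 100 mg/kg in this assay, at which 3 of the 3 values shown sit, compound 4 is expected to give about 150 mg/kg, most likely between 60 mg/kg and 500 mg/kg. That estimate corresponds to an expected step that the limit leaves unreadable from compound 3 to compound 4.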

Compound 4, dose for half-maximal effect: > 100 mg/kg
Compound 4 was reported as a limit; the forecaster's own chance of this, stated with the estimate: 85%; the middle value lies beyond the limit too.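

Compound 4 gives > 100 mg/kg, again a limit, so neither of its steps, from compound 3 or from compound 2, can be read. The compounds shown leave open how far any of them lies beyond that shared limit in this assay: the limit of > 100 mg/kg in this assay, at which 4 of the 4 values shown sit.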